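Rearranging the Fluorines of a Difluorophenyl Group

A few compounds are considered here, and "the series" means these few. Any claim that something is new, unique, unknown or untested is made for them only; others in the source may bear on it.

Compounds measured in a functional assay on Raji cells (Homo sapiens) for cytotoxicity, read by MTT assay, with a stated time of 48 h; a higher number here means a weaker inhibitor, a lower number a stronger inhibitor:
- Compound 1 `N#Cc1ccc(Cn2c(/C=C3\SC(=S)N(CC(=O)O)C3=O)nc3ccccc32)cc1`: 9780 nM
- Compound 2 `O=C(O)CN1C(=O)/C(=C/c2nc3ccccc3n2Cc2ccc(F)cc2F)SC1=S`: 8960 nM

Compound 2, at 8960 nM, stands level with compound 1 within the usual scatter of repeated measurements. The next compound, compound 3 `O=C(O)CN1C(=O)/C(=C/c2nc3ccccc3n2Cc2ccc(F)c(F)c2)SC1=S`, has not yet been measured. It differs from compound 2 in one place: 3,4-difluorophenyl in place of 2,4-difluorophenyl on a saturated chain carbon bound to an aromatic nitrogen. That is, 3,4-difluorophenyl replaces 2,4-difluorophenyl on a saturated chain carbon bound to an aromatic nitrogen. Among the measured compounds shown here, the only measured step at this place is a 1.1-fold lower number from compound 1 to compound 2 (0.04 log units; within the scatter). It exchanged one group for a quite different one, yet the number stayed within the scatter. For the measured compounds named here, no measured compound yet carries the 3,4-difluorophenyl group, so no direction can be foreseen in this assay. The estimated step, a 1.0-fold higher number from compound 2 to compound 3 (0.00 log units; within the scatter), is expected to stay within the scatter. For compound 3 the expected value is 9000 nM, with an estimated range of 5000 nM to 16000 nM.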

Compound 3, half-maximal inhibitory concentration: 7250 nM
For compound 3 the middle estimate is 1.2-fold (0.09 log units) above the measured one, within the range that was stated.
By their numbers in this assay, from the lowest: compounds 3, 2 and 1 (each within the scatter of the next).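

Moving the fluorines from the 2,4-difluorophenyl to the 3,4-difluorophenyl arrangement keeps the same atoms but joins them differently, and it gives a 1.2-fold lower number from compound 2 to compound 3 (0.09 log units; within the scatter) in this assay. Among the compounds shown here, this position has therefore now absorbed both a swap of one group for another and a simple rearrangement of fluorines without the number leaving the scatter, and the 3,4-difluorophenyl group against the 4-cyanophenyl group gives a 1.3-fold lower number from compound 1 to compound 3 (0.13 log units; within the scatter), so no compound of the three stands apart. Nothing measured here offers an explanation for this flat result.

Going by these compounds, all three compounds carry a substituted phenyl group at this place, so it remains open whether a plain phenyl group, an amine, a carboxylic acid or a longer chain would behave the same way. Whether any change here can move the number beyond the scatter is also unanswered.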